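The source may report more compounds than this note shows. Statements on the series, on what has been measured and on what is new or still open speak of the compounds shown alone.

Measured compounds:
compound 1 `O=c1ccc2cc(OCc3cc(-c4ccc(Cl)cc4)no3)ccc2o1`, in a functional assay on A549 cells (Homo sapiens) for cytotoxicity, read by MTT assay, with a stated time of 48 h; a higher number here means a weaker inhibitor, a lower number a stronger inhibitor: "not determined" (no result reported)
compound 2 `O=c1ccc2cc(OCc3cc(-c4cccc([N+](=O)[O-])c4)no3)ccc2o1`, in this assay: 36200 nM

Among the measured compounds shown here, compound 2 thus carries the only number in this assay, since compound 1 has no result there, so no step between measured compounds can be drawn. Compound 3 `N#Cc1ccccc1-c1cc(COc2ccc3oc(=O)ccc3c2)on1` differs from compound 2 by 2-cyanophenyl in place of 3-nitrophenyl on an aromatic carbon. For the measured compounds named here, with a single value and no measured step to learn from, no change beyond the usual scatter is expected in this assay, in either direction. Compound 3 is therefore estimated at 40000 nM, within 12000 nM to 120000 nM, an expected step of a 1.1-fold higher number from compound 2 to compound 3 (0.04 log units; within the scatter).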

Compound 3, half-maximal inhibitory concentration: 55800 nM
Beside the measured number, compound 3's estimate is 1.4-fold (0.14 log units) below it; the measured number falls inside the stated range.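

Placing 2-cyanophenyl in place of 3-nitrophenyl on the aromatic carbon next to the ring nitrogen gives, in this assay, a 1.5-fold higher number from compound 2 to compound 3 (0.19 log units; within the scatter). Among the compounds shown here, this is the first measured step at this position, and it shows that one substituted phenyl can replace the other there without a change beyond the usual scatter. No measurement at hand explains this step. Still open, from the compounds shown here alone, is whether a plain phenyl, or a different kind of group on that carbon, such as an amine, a carboxylic acid or a longer alkyl chain, would move the number beyond the scatter.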